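The source may hold more compounds than are shown below. What is called first, only, known or untested is meant among the compounds shown, and "the series" means these compounds.

Compound 1 `O=c1[nH]cnc2c1c(-c1ccoc1)cn2[C@@H]1O[C@H](CO)[C@@H](O)[C@H]1O`: in a functional assay on K562 cells (Homo sapiens), read by MTT assay, with a stated time of 72 h (on this read-out higher numbers stand for weaker inhibition and lower numbers for stronger inhibition), compound 1 gives 12500 nM.
Compound 2 `CSc1ncnc2c1c(-c1ccccc1)cn2[C@@H]1O[C@H](CO)[C@@H](O)[C@H]1O`: in this assay compound 2 gives only a limit, > 20000 nM.
Compound 3 `O=c1[nH]cnc2c1c(-c1cccs1)cn2[C@@H]1O[C@H](CO)[C@@H](O)[C@H]1O`: in this assay compound 3 gives only a limit, > 20000 nM.

Compound 3 thus stands at the limit of this assay, with no number of its own; two of the three values shown sit at the limit of > 20000 nM in this assay, at which 2 of the 3 values shown sit. Compound 4 `O=c1[nH]cnc2c1c(-c1ccsc1)cn2[C@@H]1O[C@H](CO)[C@@H](O)[C@H]1O` differs from compound 3 by thiophen-3-yl in place of thiophen-2-yl on an aromatic carbon. Among the compounds with values here, the one measured step that touches this part of the core is an at least 1.6-fold higher number from compound 1 to compound 3 (0.20 log units; that floor lies within the scatter), and its floor lies within the scatter, so no direction is established there. Since compound 1 does give a number where compound 3 gives only a limit, compound 4 is expected to land near the value of compound 1, giving an at least 1.3-fold lower number from compound 3 to compound 4 (0.12 log units; that floor lies within the scatter). The estimate for compound 4 is 15000 nM, within 6000 nM to 40000 nM.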

Compound 4, half-maximal inhibitory concentration: > 20000 nM
Compound 4 was reported as a limit; the forecaster's own chance of this, stated with the estimate: 45%; at least 1.3-fold (0.12 log units) between middle value and limit.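

Compound 4, with thiophen-3-yl, is a limit in this assay, as is compound 3 with thiophen-2-yl, so the step between them cannot be read. Thiophen-3-yl in place of furan-3-yl gives an at least 1.6-fold higher number from compound 1 to compound 4 (0.20 log units; that floor lies within the scatter), so neither thiophene attachment sets a direction against compound 1. The series now gathers mostly at one limit: the limit of > 20000 nM in this assay, at which 3 of the 4 values shown sit.

On these data alone, whether any group on this aromatic carbon reads clearly apart from compound 1 stays open. An aminomethyl group or a carboxylic acid here would test that.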